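The compounds below may be only part of what the source reports. "The series", "measured", "known", "first", "only" and "open" are said of these compounds alone.

Compound 1 `C=CCc1cc(C(C)=O)c(O)cc1OCCCCC#N`: 57% in an assay on isolated protein for binding affinity to leukotriene B4 receptor 1 (Homo sapiens), tested at 1 uM; on this read-out lower numbers stand for less inhibition and higher numbers for more inhibition at the one concentration tested (going by the name of the read-out)
Compound 2 `C=CCc1cc(C(C)=O)c(O)cc1OCCCCCCC`: 8% in this assay
Compound 3 `C=CCc1cc(C(C)=O)c(O)cc1OCCCCCC(=O)NO`: 28% in this assay

Among these three, compound 3 sits second highest: the step of a number 20 percentage points higher from compound 2 to compound 3 (beyond the scatter) lifts it above compound 2, while the step of a number 29 percentage points lower from compound 1 to compound 3 (beyond the scatter) leaves it short of compound 1. Compound 4 `C=CCc1cc(C(C)=O)c(O)cc1OCCCCCC(=O)N(C)C` differs from compound 3 in one place: dimethylamino in place of hydroxyamino on a carbonyl carbon.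

For the measured compounds named here, two measured steps bear on this change. In a number 29 percentage points lower from compound 1 to compound 3 (beyond the scatter) and a number 20 percentage points higher from compound 2 to compound 3 (beyond the scatter), the hydroxycarbamoyl end stands between the nitrile of compound 1 and the plain chain of compound 2. Replacing hydroxyamino by dimethylamino removes the donors and the acceptor that the hydroxycarbamoyl end brought, which moves compound 4 closer in its tail to compound 2. Since compound 2 gives 8%, a modest fall in this assay is expected, though the dimethylcarbamoyl tail is not a plain chain either.

For compound 4 the expected step is a number 13 percentage points lower from compound 3 to compound 4 (beyond the scatter), giving an estimated 15% with a range from 0% to 35%.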

Compound 4, a percentage reported as inhibition, at one concentration (the size of the read-out at that concentration, not a potency): 54%
Estimate against measurement, compound 4: 39 percentage points below; the measured number lies above the stated range.
By their numbers in this assay, from the lowest: compound 2; then compound 3; then compounds 4 and 1 (each within the scatter of the next).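

In this assay, the number is higher with dimethylamino on the carbonyl carbon than with hydroxyamino (with a number 26 percentage points higher from compound 3 to compound 4 (beyond the scatter)), so removing the hydrogen-bond donors of hydroxyamino does not lower the number here. The dimethylcarbamoyl tail also behaves very differently from the plain chain (with a number 46 percentage points higher from compound 2 to compound 4 (beyond the scatter)) and matches the nitrile (with a number 3 percentage points lower from compound 1 to compound 4 (within the scatter)), so a chain end without hydrogen-bond donors does not by itself give a low number. No measurement at hand explains why the number is higher with the dimethylcarbamoyl end than with the hydroxycarbamoyl end.

As far as these compounds go, it remains open whether a primary carboxamide or a monomethyl amide would read like compound 4 or compound 3, and where a carboxylic acid or an amine at the chain end would fall. A longer or shorter chain carrying dimethylcarbamoyl is also an open case.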